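The compounds below may be only part of what the source reports. "The series", "measured", "known", "first", "only" and "open" are said of these compounds alone.

For the measured compounds named here, compound 1 `Nc1nc(O)c2c(n1)n(C1OC(CO)[C@@H](O)[C@H]1O)c(=O)n2Cc1ccc(Cl)cc1` is the better of the two compounds measured so far. In a functional assay on YAC-1 cells (Mus musculus) (a lower number here means a smaller maximal response, a higher number a larger maximal response), compound 1 gives 27%, the highest of the two numbers recorded. Going by the values given here, the only other measured compound, compound 2 `C=CCn1c(=O)n(C2OC(CO[Si](C)(C)C(C)(C)C)[C@@H](O)[C@H]2O)c2nc(N)nc(O)c21`, carries a different group on the ring nitrogen and a protected sugar; in this assay compound 2 gives 6%, a number that sits well beyond the usual scatter below that of compound 1. Among the compounds with values here, no single-point step links these two compounds, so their values can only be placed side by side.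

The new compound, compound 3 `Nc1nc(O)c2c(n1)n(C1OC(CO)[C@@H](O)[C@H]1O)c(=O)n2Cc1ccc([N+](=O)[O-])cc1`, is a single-point variation of compound 1: nitro in place of chloro on an aromatic carbon. No comparable exchange has been measured here, so the size of the step is open; the account expects a step from compound 1 to compound 3 of a number 2 percentage points lower from compound 1 to compound 3 (within the scatter), not beyond the scatter. For compound 3 the estimate in this assay is 25%, expected to fall between 10% and 45%.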

Compound 3, largest response reached (reported as maximal response), in percent of the reference or control that the assay uses: 50%
Compound 3: the middle estimate sits 25 percentage points below what was measured; the whole stated range lies below it.
By their numbers in this assay, from the lowest: compound 2; then compound 1; then compound 3.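

In this assay, for the compounds shown here, the exchange of 4-chlorobenzyl for 4-nitrobenzyl gives a number 23 percentage points higher from compound 1 to compound 3 (beyond the scatter), and this is the first single-point step in the set. Where compounds 1 and 2 could only be placed side by side, this step shows that the maximal response changes with the group on the aromatic carbon para to a large group while the rest of compound 1 stays the same. No measurement shown here bears on the reason for this step.

On these data alone, how an amine, a methoxy group or a carboxylic acid at this same place would compare with chloro and nitro remains open. Also open, as far as these compounds go, is whether the step would hold with an allyl group on the ring nitrogen and a protected sugar, as in compound 2.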